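This account rests on a few compounds, and the source may have more. Where it says the series, first, only, none or still open, it means among the compounds named here.

Compound 1, `Cc1nn(-c2nc(-c3ccc(Cl)c(Cl)c3)c(SC(C)C)s2)c(C(=O)O)c1-c1ccccc1[N+](=O)[O-]`: 4700 nM
Compound 2, `Cc1c(-c2cc(Cl)cc(Cl)c2)c(C(=O)O)nn1-c1nc(-c2cc(Cl)cc(Cl)c2)c(SC(C)C)s1`: 2000 nM
Compound 3, `COC(=O)c1c(Cc2ccccc2[N+](=O)[O-])c(C)nn1-c1nc(-c2ccc(Cl)c(Cl)c2)c(SC(C)C)s1`: 93000 nM

All three were tested in a functional assay on BJAB cells (Homo sapiens) for antiproliferative activity, with a stated time of 4 days; a higher number here means that more compound is needed for the effect, a lower number that less compound is needed. Among these numbers, compound 1 stands second highest: compound 2 gives a lower value, a gap beyond the usual scatter, while compound 3 gives a much higher value, also beyond the scatter. The three structures differ from one another in several places at once, so no single change can be traced between any two of the measured compounds.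

Compound 4, `Cc1nn(-c2nc(-c3ccc(Cl)c(Cl)c3)c(SC(C)C)s2)c(C(=O)O)c1-c1ccccc1C(F)(F)F`, has not yet been measured in this assay. It differs from compound 1 in one place only: trifluoromethyl in place of nitro on an aromatic carbon. Going by the values given here, nothing among the measured compounds shows what such an exchange does in this assay. With the rest of the molecule kept the same, the step of a 1.2-fold lower number from compound 1 to compound 4 (0.07 log units; within the scatter) is expected to be modest, and may well fall within the scatter in either direction. Compound 4 is therefore estimated to give 4000 nM, with a range from 1500 nM to 12000 nM.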

Compound 4, half-maximal effective concentration: 5200 nM
Beside the measured number, compound 4's estimate is 1.3-fold (0.11 log units) below it; low and high end bracket the measured number.
By their numbers in this assay, from the lowest: compound 2; then compounds 1 and 4 (each within the scatter of the next); then compound 3.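

In this assay, going by these compounds alone, trifluoromethyl in place of nitro gives a 1.1-fold higher number from compound 1 to compound 4 (0.04 log units; within the scatter) and is the first single change that can be read in this set. On this aromatic carbon, ortho to a large group, the nitro group is therefore not required to keep the number where it stands, since a group with no hydrogen-bond acceptors serves equally well here. Nothing measured here speaks to why the two groups give such similar numbers.

On these data alone, whether a methyl group, a chlorine atom or an amine in that same place would also leave the number unchanged remains open. As far as these compounds go, it is also open whether this exchange would behave the same way with a different group in place of the carboxylic acid, such as a primary amide.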